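The source may report more compounds than this note shows. Statements on the series, on what has been measured and on what is new or still open speak of the compounds shown alone.

Measured so far: compound 1 `N=C(N)NCCC[C@@H]1NC(=O)CC(=O)N[C@@H](CC(=O)O)C(=O)N[C@H](Cc2ccccc2)CNC1=O` with 24 nM; compound 2 `N=C(N)NCCC[C@@H]1NC(=O)CC(=O)N[C@H](CC(=O)O)C(=O)N[C@@H](Cc2ccccc2)CNC1=O` with > 100000 nM.

In an assay on K562 cells for inhibition of integrin alpha-5/beta-1 (Homo sapiens), with a stated time of 30 min (on this read-out higher numbers stand for weaker inhibition and lower numbers for stronger inhibition), compound 1 gives 24 nM. Compound 2 shares all atoms and bonds with compound 1. In this assay compound 2 reaches only a limit, > 100000 nM, so for compound 2 only a limit and no number is known. The step of an at least 4100-fold higher number from compound 1 to compound 2 (3.61 log units; beyond the scatter) rests on two inverted stereocentres at saturated ring carbons; that it appears as a limit is told by the limit of > 100000 nM in this assay, at which 1 of the 2 values shown sits.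

Compound 3 `N=C(N)NCCC[C@H]1NC(=O)CC(=O)N[C@H](CC(=O)O)C(=O)N[C@H](Cc2ccccc2)CNC1=O` is the next diastereomer of the shared core. Against compound 2 it shows (the two compounds have the same atoms and bonds; at least one stereo element is drawn with a configuration in one of them and without one in the other: 2 of 4 stereo elements differ; a stereocentre at a saturated ring carbon is drawn S in compound 2 and R in compound 3; a stereocentre at a saturated ring carbon is drawn S in compound 2 and R in compound 3). Among the compounds with values here, the one measured step that bears on it is an at least 4100-fold higher number from compound 1 to compound 2 (3.61 log units; beyond the scatter), which shows that inverting two ring stereocentres can move this assay by a very large amount. Compound 3 does not restore the configuration of compound 1 at both changed centres, so a weak result in this assay is expected, though the direction from the limit of compound 2 cannot be read as a number; the estimated step is an at least 10-fold lower number from compound 2 to compound 3 (1.00 log units; beyond the scatter). Compound 3 is therefore expected to give about 10000 nM, within 300 nM to 100000 nM.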

Compound 3, half-maximal inhibitory concentration: > 100000 nM
Compound 3 ended at the assay's limit (the forecaster's own chance of this, stated with the estimate: 40%); at least 10-fold (1.00 log units) between middle value and limit.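

In this assay, within the data shown here, there is an at least 4100-fold higher number from compound 1 to compound 3 (3.61 log units; beyond the scatter) and thus a second case of the same kind: a pair of inverted ring stereocentres that is not the pair inverted in compound 2 also takes the shared core from a measured value to the limit, so the loss is not confined to the one pair seen before. For compound 3 the result is a limit and not a number: the limit of > 100000 nM in this assay, at which 2 of the 3 values shown sit. Compound 3 shares all atoms and bonds with compound 1, so this step is one of configuration alone: the fact that one of compounds 1 and 3 is drawn with a defined configuration and the other without, at the place where they differ.

From the compounds shown here alone, the step between compound 2 and compound 3 cannot be read from two limits, and it stays open whether inverting a single ring stereocentre of compound 1 would be enough to reach the limit, or how far each centre counts on its own. Also open, going by these compounds, is how this assay would respond on the core of compound 1 if the carboxylic acid were carried on a longer chain or the guanidine were replaced by a primary amine.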